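Swapping Methoxy for Trifluoromethyl on a Second Core

The source may report more compounds than this note shows. Statements on the series, on what has been measured and on what is new or still open speak of the compounds shown alone.

Compound 1 `COc1cccc(C(=O)N(CCN2CCC(OCC(=O)O)CC2)c2ccc(C)cc2)c1` gives 32 nM in a functional assay on a cell-free system (Platelet, plasma, Homo sapiens) for inhibition; a higher number here means a weaker inhibitor, a lower number a stronger inhibitor. Compound 2 `Cc1ccc(N(CCN2CCC(OCC(=O)O)CC2)C(=O)c2cccc(C(F)(F)F)c2)cc1` differs from it by trifluoromethyl in place of methoxy on an aromatic carbon and gives 20000 nM in this assay, a loss of a 630-fold higher number from compound 1 to compound 2 (2.80 log units; beyond the scatter). Compound 3 `COc1ccc(C(=O)N(CCN2CCC(OCC(=O)O)CC2)c2ccc(Cl)cc2)cc1` rests on a different core; the difference between the two cores is not broken down here. In this assay compound 3 gives 3100 nM. Compound 4 `O=C(O)COC1CCN(CCN(C(=O)c2ccc(C(F)(F)F)cc2)c2ccc(Cl)cc2)CC1` is not yet measured and differs from compound 3 by trifluoromethyl in place of methoxy on an aromatic carbon. This is the same kind of change as before, not the same: earlier the group sat meta to a large group, here it sits para to a large group. Compound 4 is expected to lose about an 8.1-fold higher number from compound 3 to compound 4 (0.91 log units; beyond the scatter), a smaller step than the earlier one. The smaller step rests on compound 3 already giving only 3100 nM. For compound 4 the estimate is 25000 nM, expected between 6000 nM and 100000 nM.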

Compound 4, half-maximal inhibitory concentration: > 10000 nM
Compound 4: only a limit was reported; the forecaster's own chance of this, stated with the estimate: 30%; the middle value lies beyond the limit too.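

In this assay compound 4 gives > 10000 nM, which is a limit of the assay and not an exact number. On this second core, trifluoromethyl in place of methoxy again gives a weaker inhibitor, with an at least 3.2-fold higher number from compound 3 to compound 4 (0.50 log units; beyond the scatter), so the direction of the change holds on both cores: the same change on two cores in this assay, a 630-fold higher number (2.80 log units; beyond the scatter) from compound 1 to compound 2 and an at least 3.2-fold higher number (0.50 log units; beyond the scatter) from compound 3 to compound 4; the limit leaves it open whether they differ These compounds do not show how large the step really is on the second core, and the group also sits at a different place in the two pairs.

Going by these compounds, it remains open whether a nitrile or a hydroxyl group in place of methoxy would retain inhibition on either core. Also open, on these data alone, is how methoxy and trifluoromethyl compare at one and the same place on a single core.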